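This account rests on a few compounds, and the source may have more. Where it says the series, first, only, none or still open, it means among the compounds named here.

Compound 1 `Cc1ccsc1-c1ccccc1NCC1=NCCN1`: 49 nM
Compound 2 `Cc1cccnc1-c1ccccc1NCC1=NCCN1`: < 100000 nM
Compound 3 `Nc1nccc(-c2ccccc2NCC2=NCCN2)n1`: 28.8 nM

The three measured compounds share a core and differ in the group attached to it. In a functional assay for activation of Alpha-1D adrenergic receptor (Homo sapiens) (a higher number here means that more compound is needed for the effect, a lower number that less compound is needed), compound 1 gives 49 nM. Compound 3 gives 28.8 nM in this assay, and these two numbers lie within the usual scatter of each other, so neither can be called more or less active than the other. For compound 2 this assay reports a limit, < 100000 nM, as noted in the limit of < 100000 nM in this assay, at which 1 of the 3 values shown sits.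

Compound 4 `CO/N=C/c1ccccc1NCC1=NCCN1` has not yet been measured. It differs from compound 1 in one place: a group of 4 heavy atoms (2 carbon, 1 nitrogen, 1 oxygen; no ring) in place of a group of 6 heavy atoms (5 carbon, 1 sulfur; one five-membered aromatic ring with 1 hetero atom), on an aromatic carbon. Among the measured compounds no pair shows a comparable exchange of a ring for an open chain, so the size of the step is uncertain. The step is expected to be a 3.1-fold higher number from compound 1 to compound 4 (0.49 log units; beyond the scatter), toward a higher number in this assay. For compound 4 the estimated value is 150 nM, expected to fall between 30 nM and 1500 nM.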

Compound 4, half-maximal effective concentration: < 5020 nM
Compound 4: no number, only a limit; the forecaster's own chance of this, stated with the estimate: 15%; the middle value is on the limit's open side.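

In this assay compound 4 gives < 5020 nM, which is a limit and not a number, so the step from compound 1 to compound 4 cannot be read. The compounds shown leave open how far the number in this assay moves when the open chain of compound 4 replaces the 3-methylthiophen-2-yl group.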